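Adding an Isopropylsulfanyl Group: Expected Effect on Vero Cytotoxicity

The source may report more compounds than this note shows. Statements on the series, on what has been measured and on what is new or still open speak of the compounds shown alone.

Measured so far:
compound 1 `Fc1ccc(-c2nn3ccc(NC4CCCC4)cc3c2-c2ccnc(NC3CCCC3)n2)cc1`: 18000 nM
compound 2 `Nc1ccn2nc(-c3ccc(F)cc3)c(-c3ccnc(NC4CCCC4)n3)c2c1`: 20000 nM

In an ADME assay on Vero cells (Chlorocebus sabaeus) for cytotoxicity (on this read-out lower numbers stand for higher toxicity in this test and higher numbers for lower toxicity in this test), compound 1 gives 18000 nM, and compound 2 sits alongside it, separated only by a 1.1-fold higher number from compound 1 to compound 2 (0.05 log units; within the scatter). The two numbers therefore cannot be told apart with confidence.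

Compound 3 `CC(C)Sc1cc(NC2CCCC2)cc2c(-c3ccnc(NC4CCCC4)n3)c(-c3ccc(F)cc3)nn12` is reached from compound 1 by isopropylsulfanyl in place of hydrogen on an aromatic carbon. Within the data shown here, no measured step touches an isopropylsulfanyl group or this position on the core of compound 1. Among the measured compounds shown here, the only measured step, a 1.1-fold higher number from compound 1 to compound 2 (0.05 log units; within the scatter), concerns a cyclopentyl group on a different part of the shared core and stayed within the scatter, so it gives little guidance about the present change. With no directional evidence, the expectation for compound 3 in this assay is a step no larger than the scatter, no change at the digits printed from compound 1 to compound 3 (within the scatter). Compound 3 is thus estimated at 18000 nM, with a range from 7000 nM to 45000 nM.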

Compound 3, half-maximal cytotoxic concentration: > 40000 nM
Compound 3 was reported as a limit (the forecaster's own chance of this, stated with the estimate: 15%); middle value at least 2.2-fold (0.34 log units) away from the limit.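

In this assay compound 3 gives > 40000 nM, and this value is a limit of the assay, not a number. Isopropylsulfanyl in place of hydrogen on the aromatic carbon next to the ring nitrogen gives an at least 2.2-fold higher number from compound 1 to compound 3 (0.34 log units; beyond the scatter), so this is the first change shown that moves the read-out beyond the scatter, and it moves towards lower toxicity in this test. Going by these compounds, how far the number really rises stays unknown, since the read-out ends at a limit: the limit of > 40000 nM in this assay, at which 1 of the 3 values shown sits.

The compounds shown leave open whether the sulfur, the isopropyl part or simply having any group at this position accounts for the step, which a methyl group or an amine at the same carbon could help to separate. They also leave open whether isopropylsulfanyl would give a similar step on compound 2.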